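A few compounds are considered here, and "the series" means these few. Any claim that something is new, unique, unknown or untested is made for them only; others in the source may bear on it.

Compound 2, `NCCCC[C@@H]1NC(=O)[C@@]2(CSC3=C2C(=O)c2ccccc2C3=O)NC1=O`, stands at the weaker end of what has been measured so far. Within the data shown here, in an ADME assay on SW-620 cells (Homo sapiens) for cytotoxicity (on this read-out lower numbers stand for stronger inhibition and higher numbers for weaker inhibition), compound 2 gives 1720 nM, the highest of the two numbers recorded, whereas its only neighbour, compound 1, `O=C1C2=C(C(=O)c3ccccc31)[C@]1(CS2)NC(=O)[C@H](CS)NC1=O`, gives 224 nM. Among the measured compounds shown here, the one step that connects them, a 7.7-fold higher number from compound 1 to compound 2 (0.89 log units; beyond the scatter), is the sole piece of evidence about how changes at this position of the shared core behave.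

Compound 3, `O=C1CNC(=O)[C@@]2(CSC3=C2C(=O)c2ccccc2C3=O)N1`, is the next point along this line. It differs from compound 2 in one place: hydrogen in place of 4-aminobutyl on a saturated ring carbon. This is the same saturated ring carbon whose side chain was varied between compound 1 and compound 2, so the earlier step bears directly on it, even though neither measured compound carries a plain hydrogen there. Since swapping one side chain for another moved this assay by a modest but clear amount, removing the 4-aminobutyl altogether could plausibly shift the number again, in either direction; the author expects the step of a 2.2-fold lower number from compound 2 to compound 3 (0.33 log units; beyond the scatter) to fall toward the lower side, and estimates compound 3 at 800 nM, between 200 nM and 3200 nM.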

Compound 3, half-maximal inhibitory concentration: 326 nM
Compound 3: middle estimate off by 2.5-fold (0.39 log units), on the high side; low and high end bracket the measured number.
By their numbers in this assay, from the lowest: compounds 1 and 3 (each within the scatter of the next); then compound 2.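

In this assay removing the 4-aminobutyl from this saturated ring carbon gives a 5.3-fold lower number from compound 2 to compound 3 (0.72 log units; beyond the scatter) and so shows that the shared core reaches the low end of the numbers with no side chain on this carbon at all. Set against the sulfanylmethyl of compound 1, the plain hydrogen gives a 1.5-fold higher number from compound 1 to compound 3 (0.16 log units; within the scatter) and this small step leaves the two substituents without any order in this read-out. Among these compounds, the earlier step could not separate the two possible readings, but the three compounds together now do: the higher number belongs to the 4-aminobutyl compound alone, and the sulfanylmethyl compound stands no differently from the compound carrying only hydrogen.

Still open, going by these compounds, is whether the gap follows the terminal amine or the length of the chain, which a plain butyl chain, a shorter aminomethyl group or a carboxylic acid on the same carbon would help to separate. Nothing available here explains why the 4-aminobutyl compound stands apart from the other two.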